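From 4-Chlorophenyl to 2-Bromophenyl on the Shared Core

The compounds below may be only part of what the source reports. "The series", "measured", "known", "first", "only" and "open" are said of these compounds alone.

In a functional assay on HL-60 cells (Homo sapiens) for antiproliferative activity, read by sulforhodamine B assay, with a stated time of 72 h (on this read-out higher numbers stand for weaker inhibition and lower numbers for stronger inhibition), compound 1 (`FC(F)(F)c1ccccc1NC(=S)N/N=C/c1ccc2ccccc2n1`) gives 13200 nM and compound 2 (`COc1cccc(NC(=S)N/N=C/c2ccc3ccccc3n2)c1`) gives 71200 nM as measured numbers. Compound 3 (`S=C(N/N=C/c1ccc2ccccc2n1)Nc1ccc(Cl)cc1`) gives > 100000 nM as a limit of the assay and not as a number. Compound 3 therefore stands at the limit of > 100000 nM in this assay, at which 1 of the 3 values shown sits, and offers no measured number to start from.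

Compound 4 (`S=C(N/N=C/c1ccc2ccccc2n1)Nc1ccccc1Br`) has not yet been measured. Its change from compound 3 is 2-bromophenyl in place of 4-chlorophenyl on an amide-type nitrogen and amounts to 2-bromophenyl in place of 4-chlorophenyl on an amide-type nitrogen. Within the data shown here, one measured step touches that same place: an at least 1.4-fold higher number from compound 2 to compound 3 (0.14 log units; that floor lies within the scatter) and it sets only a floor, not a size. Compound 1 at 13200 nM and compound 2 at 71200 nM both read as numbers, so a number for compound 4 is expected more likely than not. The expected change is an at least 3.3-fold lower number from compound 3 to compound 4 (0.52 log units; beyond the scatter) toward stronger inhibition, and its size is only an estimate. In this assay compound 4 is estimated at 30000 nM with an expected range of 9000 nM to 90000 nM and a reading at the limit remains possible.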

Compound 4, half-maximal inhibitory concentration: > 100000 nM
Compound 4 was reported as a limit; the forecaster's own chance of this, stated with the estimate: 25%; at least 3.3-fold (0.52 log units) between middle value and limit.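

In this assay compound 4 gives > 100000 nM, which is a limit of the assay and not a number, and it now shares that reading with compound 3: the limit of > 100000 nM in this assay, at which 2 of the 4 values shown sit. Among these compounds, the one readable step of real size involves bromo in place of trifluoromethyl on an aromatic carbon, with an at least 7.5-fold higher number from compound 1 to compound 4 (0.87 log units; beyond the scatter), so on the shared core the measurable activity of compound 1 does not carry over to the bromo compound. Putting 2-bromophenyl in place of 3-methoxyphenyl on the amide-type nitrogen gives an at least 1.4-fold higher number from compound 2 to compound 4 (0.14 log units; that floor lies within the scatter), a floor that lies within the scatter, while the exchange of 4-chlorophenyl for 2-bromophenyl cannot be read, as both ends are limits.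

The compounds shown therefore leave open whether 2-bromophenyl and 4-chlorophenyl differ at all, since neither gives a number to compare. They also leave open how a phenyl group carrying an amine or a carboxylic acid would read on the same amide-type nitrogen, and whether any such group would come closer to compound 1 than the halogen-bearing phenyl groups do.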